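Thiourea series on the shared core: aryl change

The source may report more compounds than this note shows. Statements on the series, on what has been measured and on what is new or still open speak of the compounds shown alone.

Measured so far in a functional assay on MKN-74 cells (Homo sapiens) for antiproliferative activity, with a stated time of 24 h; on this read-out higher numbers stand for weaker inhibition and lower numbers for stronger inhibition:
compound 1 `Cc1ccccc1CN1CCc2c(sc(NC(=O)c3ccccc3Cl)c2C(N)=O)C1` — > 50000 nM
compound 2 `NC(=O)c1c(NC(=O)c2ccccc2Cl)sc2c1CCN(C(=S)Nc1ccccc1)C2` — 15600 nM
compound 3 `NC(=O)c1c(NC(=O)c2ccccc2Cl)sc2c1CCN(C(=S)Nc1ccccc1F)C2` — 12600 nM

Compound 1 gives only a limit of this assay, (the limit of > 50000 nM in this assay, at which 1 of the 3 values shown sits). Compound 2 and compound 3 both give numbers. Compound 3 holds the lower of the two numbers shown, with compound 2 nearest; the pair sit within the scatter of each other, so no order between them is claimed. The steps from the limit are an at least 3.2-fold lower number from compound 1 to compound 2 (0.50 log units; beyond the scatter) and an at least 3.9-fold lower number from compound 1 to compound 3 (0.59 log units; beyond the scatter), and the step between the two thioureas is a 1.2-fold lower number from compound 2 to compound 3 (0.09 log units; within the scatter).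

Compound 4 `COc1ccc(NC(=S)N2CCc3c(sc(NC(=O)c4ccccc4Cl)c3C(N)=O)C2)cc1` is not yet measured. It differs from compound 3 by 4-methoxyphenyl in place of 2-fluorophenyl on an amide-type nitrogen. Going by the values given here, the one measured step that bears on this kind of change, an exchange on the aryl ring attached to the thiourea nitrogen, is a 1.2-fold lower number from compound 2 to compound 3 (0.09 log units; within the scatter), which stayed within the scatter. No step shown tests a 4-methoxyphenyl group, so the expectation rests on that single comparison.

For compound 4 in this assay the expectation is a step of a 1.0-fold higher number from compound 3 to compound 4 (0.01 log units; within the scatter), that is, no change beyond the scatter. Compound 4 is therefore estimated at 13000 nM, with a range from 5000 nM to 35000 nM.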

Compound 4, half-maximal inhibitory concentration: 19600 nM
Estimate against measurement, compound 4: 1.5-fold (0.18 log units) below, and the stated range covers the measured number.
By their numbers in this assay, from the lowest: compounds 3, 2 and 4 (each within the scatter of the next). At a limit, above all of these: compound 1.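

On the amide-type nitrogen whose other neighbour is the thiocarbonyl carbon, the aryl exchange now extends to 4-methoxyphenyl, and in this assay the two new steps among the thioureas are a 1.6-fold higher number from compound 3 to compound 4 (0.19 log units; within the scatter) and a 1.3-fold higher number from compound 2 to compound 4 (0.10 log units; within the scatter), so phenyl, 2-fluorophenyl and 4-methoxyphenyl cannot be told apart on this read-out. Compound 1 stays apart from a third thiourea as well, with the step being an at least 2.5-fold lower number from compound 1 to compound 4 (0.40 log units; beyond the scatter). The size of that step is only a bound, as compound 1 gives a limit and not a number: the limit of > 50000 nM in this assay, at which 1 of the 4 values shown sits.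

Whether an aryl ring is needed on this nitrogen stays open, as the compounds shown carry no alkyl chain, pyridine ring or carboxylic acid there. Also open is which part of the thiourea carries the gap to compound 1: the steps shown replace the whole group at once, and a urea, with a carbonyl in place of the thiocarbonyl, does not stand among them.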